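A few compounds are considered here, and "the series" means these few. Any claim that something is new, unique, unknown or untested is made for them only; others in the source may bear on it.

Measured so far in an ADME assay on MT4 cells (Homo sapiens) for activation, read by MTT assay; on this read-out higher numbers stand for lower toxicity in this test and lower numbers for higher toxicity in this test:

- Compound 1 `CCCSc1nc(Cc2c(F)cccc2Cl)cc(=O)[nH]1` gives > 80000 nM as a limit
- Compound 2 `Cc1c(Cc2c(F)cccc2Cl)nc(SC(C)C)[nH]c1=O` gives > 76000 nM as a limit
- Compound 3 `CCCSc1nc(C(C)c2c(F)cccc2Cl)cc(=O)[nH]1` gives > 75000 nM as a limit

All three compounds thus end in limits and none gives a number. Compound 3 therefore has no exact place on the scale, and the same holds for the two others.

The next compound is compound 4 `CCCCSc1nc(C(C)c2c(F)cccc2Cl)cc(=O)[nH]1`, reached from compound 3 by methyl in place of hydrogen on a saturated chain carbon, three bonds along the chain from a sulfur on the sulfur chain. Cut one bond further out, the same difference reads propyl to butyl. Among the measured compounds shown here, only one measured step bears on it, and that step is also a methyl in place of hydrogen, though at another place: a step that the two limits leave unreadable from compound 1 to compound 3 is all that the data show. For the measured compounds named here, it offers no size to carry over, and no measured step shows a change of chain length at this place.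

With compound 3 at > 75000 nM as a limit, no step beyond the scatter is expected in this assay, and another limit is the likely report. For compound 4 the estimated value is 70000 nM within an expected range of 28000 nM to 110000 nM as estimated here. This estimate means an expected at least 1.0-fold lower number from compound 3 to compound 4 (0.02 log units; that floor lies within the scatter) in all.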

Compound 4, half-maximal cytotoxic concentration: > 73000 nM
Compound 4 was reported as a limit; the forecaster's own chance of this, stated with the estimate: 70%; at least 1.0-fold (0.01 log units) between middle value and limit.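

Compound 3 and compound 4 are both reported as limits in this assay, and the step between them cannot be read. The compounds shown leave open where any of them would sit on the scale as an exact number, and whether the change from propyl to butyl shifts the read-out at all.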